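Amine substituent notes toward compound 4

This account rests on a few compounds, and the source may have more. Where it says the series, first, only, none or still open, it means among the compounds named here.

Measured so far in a functional assay on MGC-803 cells (Homo sapiens) for inhibition, read by sulforhodamine B assay; on this read-out higher numbers stand for weaker inhibition and lower numbers for stronger inhibition:
compound 1 `O=C1C(N2CCCCC2)=CC(=O)c2c1nc1n2[C@H]2OC[C@@H](O)[C@H]2OC1`: > 4000 nM, a limit of the assay
compound 2 `O=C1C=C(NCc2ccccc2)C(=O)c2c1nc1n2[C@H]2OC[C@@H](O)[C@H]2OC1`: 2670 nM
compound 3 `CCCN(CCC)C1=CC(=O)c2c(nc3n2[C@H]2OC[C@@H](O)[C@H]2OC3)C1=O`: > 16000 nM, a limit of the assay

Among the compounds with values here, compound 2 stands alone as the only number in the set; the other two values are limits. Within the data shown here, the one measured step, a step that the two limits leave unreadable from compound 1 to compound 3, gives no readable size, since both ends sit at limits (the limit of > 16000 nM in this assay, at which 1 of the 3 values shown sits, (the limit of > 4000 nM in this assay, at which 1 of the 3 values shown sits)).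

Compound 4 `O=C1C=C(Nc2ccccc2F)C(=O)c2c1nc1n2[C@H]2OC[C@@H](O)[C@H]2OC1` differs from compound 2 by 2-fluorophenyl in place of benzyl on an amine nitrogen. No readable measured step bears on this change, so no movement beyond the usual scatter is expected; the step from compound 2 to compound 4 is estimated as a 1.0-fold higher number from compound 2 to compound 4 (0.00 log units; within the scatter). For compound 4 the expected value in this assay is 2700 nM, with a range from 900 nM to 8000 nM.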

Compound 4, half-maximal inhibitory concentration: 2080 nM
For compound 4 the middle estimate is 1.3-fold (0.11 log units) above the measured one; low and high end bracket the measured number.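

The series now has its first readable step in this assay, a 1.3-fold lower number from compound 2 to compound 4 (0.11 log units; within the scatter) and the earlier step, between two limits, could not be read. On the amine nitrogen, benzyl and 2-fluorophenyl therefore cannot be told apart on this read-out, so compound 2 and compound 4 take no order.
Nothing measured here accounts for this result.

Still open, going by these compounds, is what the fluorine and the benzyl carbon each contribute. Plain phenylamino and the longer phenethylamino chain would address these separately.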